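Tolyl on the lactam nitrogen: a repeated change

This account rests on a few compounds, and the source may have more. Where it says the series, first, only, none or still open, it means among the compounds named here.

Measured so far in a functional assay on HepG2 cells (Homo sapiens) for antiproliferative activity, read by MTT assay, with a stated time of 72 h; on this read-out higher numbers stand for weaker inhibition and lower numbers for stronger inhibition:
- compound 1 `COc1ncc(-c2ccc3c(c2)N(c2ccc(C)cc2)C(=O)CO3)cc1NS(=O)(=O)c1ccc(F)cc1`: 28300 nM
- compound 2 `COc1ncc(-c2ccc3c(c2)NC(=O)CO3)cc1NS(=O)(=O)c1ccc(F)cc1`: 6590 nM
- compound 3 `O=C1COc2ccc(-c3cnc(Cl)c(NS(=O)(=O)c4ccc(F)cc4)c3)cc2N1`: > 40000 nM

Compound 3 gives only a limit of this assay, not a number (the limit of > 40000 nM in this assay, at which 1 of the 3 values shown sits).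

Two single changes connect the measured compounds. From compound 2 to compound 1 the change is 4-methylphenyl in place of hydrogen on an amide-type nitrogen in a ring, and it gives a 4.3-fold higher number from compound 2 to compound 1 (0.63 log units; beyond the scatter). From compound 2 to compound 3 the core changes by chloro in place of methoxy on an aromatic carbon, which gives an at least 6.0-fold higher number from compound 2 to compound 3 (0.78 log units; beyond the scatter); since compound 3 sits at a limit, this step is known only as a lower bound.

Compound 4 `Cc1ccc(N2C(=O)COc3ccc(-c4cnc(Cl)c(NS(=O)(=O)c5ccc(F)cc5)c4)cc32)cc1` is not yet measured. It differs from compound 3 by 4-methylphenyl in place of hydrogen on an amide-type nitrogen in a ring. The place of this change is the same word for word as in the change from compound 2 to compound 1, so it is the same change on the other core. Within the data shown here, the only measured instance of it, from compound 2 to compound 1, raised the number beyond the scatter.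

The expectation for compound 4 rests on that one instance. Starting from compound 3, which is already at a limit, the step is expected to be a step that the limit leaves unreadable from compound 3 to compound 4, comparable in direction to a 4.3-fold higher number from compound 2 to compound 1 (0.63 log units; beyond the scatter). For compound 4 in this assay the estimate is 150000 nM, with a range from 45000 nM to 500000 nM, and a reported limit rather than a number is expected to be the most likely outcome.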

Compound 4, half-maximal inhibitory concentration: 39600 nM
Estimate against measurement, compound 4: 3.8-fold (0.58 log units) above; the measured number lies below the stated range.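

In this assay, the 4-methylphenyl change on the amide-type nitrogen gives a number no higher from compound 3 to compound 4 (the limit leaves the size open) and does not carry over unchanged from the core of compound 2 to the core of compound 3: the same change on two cores in this assay, a 4.3-fold higher number (0.63 log units; beyond the scatter) from compound 2 to compound 1 and a number no higher (the limit leaves the size open) from compound 3 to compound 4, at least 4.3-fold (0.63 log units) apart, beyond the scatter of two such steps

The exchange of methoxy for chloro also reads differently on the two cores, with a 1.4-fold higher number from compound 1 to compound 4 (0.15 log units; within the scatter) on the substituted core: the same change on two cores in this assay, an at least 6.0-fold higher number (0.78 log units; beyond the scatter) from compound 2 to compound 3 and a 1.4-fold higher number (0.15 log units; within the scatter) from compound 1 to compound 4, at least 4.3-fold (0.63 log units) apart, beyond the scatter of two such steps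

Compound 3 is a limit, > 40000 nM, and the size of its step to compound 4 cannot be read, so these pairs show a difference between two cores but give no size for the change on the chloro core and no rule for any further core.

Open, as far as these compounds go, is whether this difference belongs to 4-methylphenyl itself or to any group on that nitrogen, which a methyl or a longer alkyl chain there would test on both cores. Also open, from the compounds shown here alone, is how other groups in place of the methoxy, such as an amine, would behave with and without the 4-methylphenyl group.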